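Moving the fluorine on a phenoxy side chain

The compounds below may be only part of what the source reports. "The series", "measured", "known", "first", "only" and "open" are said of these compounds alone.

Compound 1 `O=C1C(=O)N(Cc2ccc(F)cc2)c2ccc(S(=O)(=O)N3CCCC3)cc21` in an assay on isolated protein for inhibition of Caspase-8 (Homo sapiens) (a lower number here means that less compound is needed, a higher number that more compound is needed for the effect), gives > 5000 nM. Compound 2 `O=C1C(=O)N(Cc2ccc(F)cc2)c2ccc(S(=O)(=O)N3CCC[C@H]3COc3ccc(F)cc3)cc21` gives > 5000 nM.

Both numbers are limits of this assay, not measured concentrations. Compound 2 stands at the limit: its true value could be anywhere at or beyond it, and nothing more about it is known. The step that the two limits leave unreadable from compound 1 to compound 2 therefore cannot be read in size or direction, which follows from the limit of > 5000 nM in this assay, at which 2 of the 2 values shown sit.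

Compound 3 `O=C1C(=O)N(Cc2ccc(F)cc2)c2ccc(S(=O)(=O)N3CCC[C@H]3COc3cccc(F)c3)cc21` shares everything with compound 2 except one detail: 3-fluorophenyl in place of 4-fluorophenyl on an oxygen on a saturated carbon. The fluorine of the side-chain ring is thus moved, with no change in the count of atoms.

Among the compounds with values here, no measured step bears readably on this change, since the only step available is unreadable. With compound 2 at the limit, the step to compound 3 can only be judged as a guess: the closest measured compounds are both at the limit, so compound 3 is expected to stay near it as well, and the expected step is a step that the limit leaves unreadable from compound 2 to compound 3. Compound 3 is estimated at 8000 nM, within 2000 nM to 40000 nM.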

Compound 3, half-maximal effective concentration: > 5000 nM
Compound 3: only a limit was reported (the forecaster's own chance of this, stated with the estimate: 85%); the middle value lies beyond the limit too.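

Compound 3 also sits at a limit of this assay, so neither its step from compound 2 nor its step from compound 1 can be read in size or direction: the limit of > 5000 nM in this assay, at which 3 of the 3 values shown sit.

The compounds shown leave open whether moving the fluorine from 4-fluorophenoxy to 3-fluorophenoxy changes the result in this assay at all.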